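The source may hold more compounds than are shown below. What is called first, only, known or untested is meant among the compounds shown, and "the series" means these compounds.

Compound 1 `Cc1cnc(Nc2ccc(S(C)(=O)=O)cc2)nc1Nc1nc2ccccc2s1` gives 14800 nM in a functional assay on MDA-MB-231 cells (Homo sapiens) for antiproliferative activity, read by MTT assay, with a stated time of 48 h (a lower number here means a stronger inhibitor, a higher number a weaker inhibitor), the lowest of the three numbers shown, although its steps to the other two compounds stay within the scatter. Compound 3 `Cc1cnc(Nc2ccc(S(N)(=O)=O)cc2)nc1Nc1nc2ccccc2s1` gives 16800 nM and compound 2 `Cc1cnc(Nc2ccc([N+](=O)[O-])cc2)nc1Nc1nc2ccccc2s1` gives 22500 nM in this assay; the steps of a 1.1-fold higher number from compound 1 to compound 3 (0.06 log units; within the scatter), a 1.5-fold higher number from compound 1 to compound 2 (0.18 log units; within the scatter) and a 1.3-fold lower number from compound 2 to compound 3 (0.13 log units; within the scatter) were all within the scatter. Compound 4 `Cc1cnc(Nc2ccc(S(C)(=O)=O)cc2)nc1Nc1nc2ccc(F)cc2s1` differs from compound 1 by fluoro in place of hydrogen on an aromatic carbon. Among the compounds with values here, no measured step touches this part of the molecule; the measured steps all changed the group on the other aromatic ring, and none moved the number beyond the scatter. Compound 4 is therefore expected to show a 1.1-fold lower number from compound 1 to compound 4 (0.02 log units; within the scatter) in this assay, a change not beyond the scatter. The estimate for compound 4 is 14000 nM, within a range from 6000 nM to 33000 nM.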

Compound 4, half-maximal inhibitory concentration: > 50000 nM
Compound 4 was reported as a limit (the forecaster's own chance of this, stated with the estimate: 5%); middle value at least 3.5-fold (0.55 log units) away from the limit.
By their numbers in this assay, from the lowest: compounds 1, 3 and 2 (each within the scatter of the next). At a limit, above all of these: compound 4.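

In this assay, fluoro in place of hydrogen on an aromatic carbon of the fused system gives an at least 3.3-fold higher number from compound 1 to compound 4 (0.52 log units; beyond the scatter), the only step among these compounds that lies beyond the scatter. This position therefore responds to a change, whereas the three changes on the other aromatic ring all stayed within the scatter. Compound 4 is reported only as a limit, so the full size of this step stays unknown: the limit of > 50000 nM in this assay, at which 1 of the 4 values shown sits.

On these data alone, whether a different group here, such as chloro, methoxy or an amine, would raise the number as well remains open. So does whether fluoro would do the same alongside sulfamoyl or nitro on the other aromatic ring.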